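Swapping 4-methoxyphenyl for pyridin-2-yl: an estimate

The compounds below may be only part of what the source reports. "The series", "measured", "known", "first", "only" and "open" are said of these compounds alone.

compound 1 `C/C(=N\NC(N)=O)c1ccc2c(c1)nc(-c1ccccn1)n2C1CCCCC1` gives > 100000 nM (a limit)
compound 2 `C/C(=N\NC(N)=S)c1ccc2c(c1)nc(-c1ccc(C(F)(F)F)cc1)n2C1CCCCC1` gives > 100000 nM (a limit)
compound 3 `COc1ccc(-c2nc3cc(/C(C)=N/NC(N)=S)ccc3n2C2CCCCC2)cc1` gives "not determined" (no result reported) (no result)

These values come from an ADME assay on BHK-21 cells (Mesocricetus auratus) for cytotoxicity, read by MTT assay (a lower number here means that less compound is tolerated, a higher number that more compound is tolerated), and the two entries with a sign are limits of the assay, not numbers. Compound 3 has no place on this scale, as its entry reads "not determined" (no result reported) and offers no number to start from. Compound 4 `C/C(=N\NC(N)=S)c1ccc2c(c1)nc(-c1ccccn1)n2C1CCCCC1` is still unmeasured. It carries pyridin-2-yl in place of 4-methoxyphenyl on an aromatic carbon. Going by the values given here, no measured step is available as a guide. No change beyond the usual scatter is expected in this assay and that expectation rests only on the limit of > 100000 nM in this assay, at which 2 of the 3 values shown sit, as the nearest evidence. Compound 4 is estimated at about 100000 nM with an expected range from 30000 nM to 200000 nM as its bounds.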

Compound 4, half-maximal cytotoxic concentration: 24000 nM
Beside the measured number, compound 4's estimate is 4.2-fold (0.62 log units) above it, and the stated range ends above it.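

In this assay, the group at this position can change the outcome: pyridin-2-yl in place of 4-(trifluoromethyl)phenyl gives an at least 4.1-fold lower number from compound 2 to compound 4 (0.61 log units; beyond the scatter). Pyridin-2-yl does not decide the result alone, as the sulfur-containing group in place of the oxygen-containing group on the amine nitrogen gives an at least 4.1-fold lower number from compound 1 to compound 4 (0.61 log units; beyond the scatter). Both sizes are minimum figures, because compound 1 and compound 2 sit at a limit of the assay, not at a number: the limit of > 100000 nM in this assay, at which 2 of the 4 values shown sit.

With no result for compound 3, the 4-methoxyphenyl group cannot be compared. As far as these compounds go, how a ring bearing an amine or a carboxylic acid would behave at this position remains open.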